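From phenyl to benzyl on the sulfur of compound 3

This account rests on a few compounds, and the source may have more. Where it says the series, first, only, none or still open, it means among the compounds named here.

In a functional assay on the whole organism with Mus musculus as the target (a lower number here means that less compound is needed, a higher number that more compound is needed for the effect), compound 1 `Cc1c(C)c2c(c(C)c1N)CC(C)(C)O2` gives 7.8 mg/kg. Compound 2 `CC1(C)Cc2cc(N)ccc2O1` reaches only a limit, > 100 mg/kg. Compound 3 `Cc1c(C)c2c(c(C)c1N)CC(C)(CSc1ccccc1)O2` gives 24.7 mg/kg, the highest of the two actual numbers. The phenylsulfanyl in place of hydrogen on a saturated chain carbon gives a 3.2-fold higher number from compound 1 to compound 3 (0.50 log units; beyond the scatter), a modest step and the only measured one bearing on what follows. Compound 4 `Cc1c(C)c2c(c(C)c1N)CC(C)(CSCc1ccccc1)O2` has benzyl in place of phenyl on a sulfur. For the measured compounds named here, no measured step alters this group itself, so a change beyond the scatter in this assay is not expected. The expected step is a 1.1-fold higher number from compound 3 to compound 4 (0.05 log units; within the scatter). Compound 4 is estimated at 28 mg/kg, with an expected range of 11 mg/kg to 70 mg/kg.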

Compound 4, dose for 50% inhibition: 32 mg/kg
Beside the measured number, compound 4's estimate is 1.1-fold (0.06 log units) below it; low and high end bracket the measured number.
By their numbers in this assay, from the lowest: compound 1; then compounds 3 and 4 (each within the scatter of the next). At a limit, above all of these: compound 2.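

Benzyl in place of phenyl on a sulfur gives a 1.3-fold higher number from compound 3 to compound 4 (0.11 log units; within the scatter) and so, in this assay, this position takes the larger group with no change that can be told from the scatter. For the compounds shown here, the earlier compounds showed only the step of adding phenylsulfanyl, not whether the group on the sulfur itself matters, and compound 3 and compound 4 now stand level. Nothing measured here offers a cause for this result.

Still open, on these data alone, is whether a longer chain on the sulfur, or an amine or carboxylic acid on its aromatic ring, would shift the number in this assay at all.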